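Chloro on an Aromatic Carbon: Series Notes

A few compounds are considered here, and "the series" means these few. Any claim that something is new, unique, unknown or untested is made for them only; others in the source may bear on it.

Measured so far:
compound 1 `O=C(COc1ccc(C(=O)/C=C/c2cccc(Cl)c2)cc1)N[C@H]1CCOC1=O` gives 4990 nM
compound 3 `O=C(COc1ccc(C(=O)/C=C/c2ccccc2)cc1)N[C@H]1CCOC1=O` gives 56800 nM
compound 2 `O=C(CNc1ccccc1)N[C@H]1CCOC1=O` gives only a limit, > 64000 nM

Both compound 1 and compound 3 were read in a functional assay on PC-3 cells (Homo sapiens) for antiproliferative activity, read by MTT assay, with a stated time of 72 h; on this read-out higher numbers stand for weaker inhibition and lower numbers for stronger inhibition. Between them stands (chloro in place of hydrogen on an aromatic carbon), and the step is an 11-fold lower number from compound 3 to compound 1 (1.06 log units; beyond the scatter). The limit for compound 2 is the limit of > 64000 nM in this assay, at which 1 of the 3 values shown sits. How the core of compound 2 differs from that of compound 3 is not broken down here. Compound 4 `O=C(CNc1ccccc1Cl)N[C@H]1CCOC1=O` is not yet measured; it differs from compound 2 by chloro in place of hydrogen on an aromatic carbon. Around the place the two differ: ortho to a large group in compound 4 against meta to a large group in compound 1, so this is the same kind of change, not the same. A step of similar direction is expected, an at least 2.1-fold lower number from compound 2 to compound 4 (0.32 log units; beyond the scatter), resting on an 11-fold lower number from compound 3 to compound 1 (1.06 log units; beyond the scatter) alone. Compound 4 is expected near 30000 nM, between 8000 nM and 90000 nM.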

Compound 4, half-maximal inhibitory concentration: > 64000 nM
Compound 4 was reported as a limit (the forecaster's own chance of this, stated with the estimate: 45%); middle value at least 2.1-fold (0.32 log units) from the limit.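

Compound 2 and compound 4 are both reported only as limits in this assay, so no step can be read between them: the limit of > 64000 nM in this assay, at which 2 of the 4 values shown sit.

From the compounds shown here alone, whether chloro in place of hydrogen on an aromatic carbon changes the number on the core of compound 2 remains open.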